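Compound 2 to compound 4: a methylfuran in the series

This account rests on a few compounds, and the source may have more. Where it says the series, first, only, none or still open, it means among the compounds named here.

- compound 1 `COc1ccc(/C=C/C(=O)/C=C/c2cc(OC)c(OC)c(OC)c2)cc1OC` gives 1210 nM
- compound 2 `COc1ccc(/C=C/C(=O)C(=Cc2ccc(F)cc2)C(=O)/C=C/c2ccc(OC)c(OC)c2)cc1OC` gives 550 nM
- compound 3 `COc1cc(/C=C/C(=O)C(=Cc2ccc(OC)c(OC)c2)C(=O)/C=C/c2ccc(O)c(OC)c2)ccc1O` gives 430 nM

All three values come from a functional assay on A549 cells (Homo sapiens) for inhibition, read by sulforhodamine B assay, with a stated time of 48 h (on this read-out higher numbers stand for weaker inhibition of growth and lower numbers for stronger inhibition of growth), and compound 2 lies within the scatter of compound 3 but beyond the scatter from compound 1, on the lower side. Compound 4 `COc1ccc(/C=C/C(=O)C(=Cc2ccc(C)o2)C(=O)/C=C/c2ccc(OC)c(OC)c2)cc1OC` differs from compound 2 as follows 5-methylfuran-2-yl in place of 4-fluorophenyl on a double-bonded chain carbon bound to a double-bonded chain carbon with the change on a double-bonded chain carbon bound to a double-bonded chain carbon. For the measured compounds named here, no step between measured compounds isolates this change in this assay and the only guide is compound 3, which differs from compound 2 in several places, yet compound 3 gives 430 nM within the scatter of the value of compound 2. The expected 1.2-fold lower number from compound 2 to compound 4 (0.07 log units; within the scatter) stays within the scatter, with no direction favoured. For compound 4 the estimated value is 470 nM with an expected range from 190 nM to 1150 nM as the working window.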

Compound 4, concentration for 50% growth inhibition: 1310 nM
Compound 4: middle estimate off by 2.8-fold (0.45 log units), on the low side; measured number outside the range, above it.
By their numbers in this assay, from the lowest: compounds 3 and 2 (each within the scatter of the next); then compounds 1 and 4 (each within the scatter of the next).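

At the double-bonded chain carbon bound to a double-bonded chain carbon, the group is not interchangeable: in this assay, 5-methylfuran-2-yl in place of 4-fluorophenyl gives a 2.4-fold higher number from compound 2 to compound 4 (0.38 log units; beyond the scatter) and so weaker inhibition of growth. For the compounds shown here, the earlier compounds held no step at this place, so this is the first reading of it. No measured evidence bears on the reason for this step.

The step does not separate the ring change from the methyl. On these data alone, whether furan-2-yl without the methyl, or a phenyl carrying a dimethylamino group, would stand nearer compound 2 or compound 4 remains open.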